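The source may report more compounds than this note shows. Statements on the series, on what has been measured and on what is new or still open speak of the compounds shown alone.

compound 1 `CN(C[C@H]1Cc2c(cccc2N2CCN(C3COC3)CC2)CN1)[C@H]1CCCc2cccnc21` gives 50.8%
compound 2 `C[C@@H]1CN(c2cccc3c2C[C@H](CN(C)[C@H]2CCCc4cccnc42)NC3)C[C@H](C)N1` gives 85.6%
compound 3 `CN(C[C@H]1Cc2c(cccc2N2CCN3CCC[C@H]3C2)CN1)[C@H]1CCCc2cccnc21` gives 40.1%

In an ADME assay on microsomes from liver (Mus musculus) for metabolic stability, read by LC-MS, with a stated time of 10 min (on this read-out lower numbers stand for a less stable compound and higher numbers for a more stable compound), compound 3 gives 40.1% as the lowest of the three numbers. Compound 4 `C[C@@H]1CN(c2cccc3c2C[C@H](CN(C)[C@H]2CCCc4cccnc42)NC3)C[C@H](C)N1C` has not yet been measured. Its change from compound 3 is a group of 9 heavy atoms (7 carbon, 2 nitrogen; one six-membered non-aromatic ring with 2 hetero atoms) in place of a group of 9 heavy atoms (7 carbon, 2 nitrogen; one five-membered non-aromatic ring with 1 hetero atom, one six-membered non-aromatic ring with 2 hetero atoms), on an aromatic carbon and it removes the two-ring group in favour of 3,4,5-trimethylpiperazin-1-yl.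

The closest evidence is a number 45.5 percentage points lower from compound 2 to compound 3 (beyond the scatter) where that same two-ring group replaced 3,5-dimethylpiperazin-1-yl. This was a large step, so leaving the two-ring group may win back part of it. The step of a number 10.7 percentage points lower from compound 1 to compound 3 (beyond the scatter) is modest, while a number 34.8 percentage points higher from compound 1 to compound 2 (beyond the scatter) is large and shows how much the piperazine substituents can matter. Going by the values given here, no measured compound carries the trimethyl group itself, so the full height of compound 2 cannot be assumed.

A rise is therefore expected, with a number 21.9 percentage points higher from compound 3 to compound 4 (beyond the scatter) estimated as moderate to large. Compound 4 is expected at 62% in this assay with an estimated range of 42% to 82%.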

Compound 4, percent of the compound remaining: 39.6%
For compound 4 the middle estimate is 22.4 percentage points above the measured one; measured number outside the range, below it.
By their numbers in this assay, from the lowest: compounds 4 and 3 (each within the scatter of the next); then compound 1; then compound 2.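

In this assay, putting methyl in place of hydrogen on the ring amine nitrogen of the 3,5-dimethylpiperazin-1-yl group gives a number 46 percentage points lower from compound 2 to compound 4 (beyond the scatter), so this one small change removes the high number of compound 2. The 3,4,5-trimethylpiperazin-1-yl group matches the two-ring group, with a number 0.5 percentage points lower from compound 3 to compound 4 (within the scatter), and compared with 4-(oxetan-3-yl)piperazin-1-yl it gives a number 11.2 percentage points lower from compound 1 to compound 4 (beyond the scatter). Among the four compounds, only compound 2 keeps a hydrogen on that piperazine nitrogen, and it alone reaches the high number, though four compounds are a small base for such a pattern.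

Nothing measured here explains the drop. Going by these compounds, it remains open whether an ethyl or an acetyl on that nitrogen would behave like methyl, and whether the two ring methyls are needed for the high number.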